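The source may hold more compounds than are shown below. What is called first, only, known or untested is meant among the compounds shown, and "the series" means these compounds.

Three compounds were measured in a functional assay on HCT-8 cells (Homo sapiens) for antiproliferative activity, read by MTT assay, with a stated time of 48 h; a lower number here means a stronger inhibitor, a higher number a weaker inhibitor:

Compound 1, `COc1ccc(C(=O)c2ccc(OC)c3c2C=CC(C)(C)O3)c(NC(=O)CN)c1`, gives 1050 nM.
Compound 2, `COc1ccc(C(=O)c2ccc3c(c2)C=CC(C)(C)O3)c(NC(=O)CN)c1`, gives 490 nM.
Compound 3, `CNCC(=O)Nc1cc(OC)ccc1C(=O)c1ccc(OC)c2c1C=CC(C)(C)O2`, gives 3460 nM.

Compound 2 stands lowest of the three; compound 1 is its nearest neighbour and compound 3 its furthest. Compound 1 and compound 2 share the amine-bearing side of the molecule but carry different cores; the difference between the two cores is not broken down here. Compound 3 differs from compound 1 by methyl in place of hydrogen on an amine nitrogen, and this change gave a 3.3-fold higher number from compound 1 to compound 3 (0.52 log units; beyond the scatter). Compound 4, `CNCC(=O)Nc1cc(OC)ccc1C(=O)c1ccc2c(c1)C=CC(C)(C)O2`, has not yet been measured in this assay. It differs from compound 2 by methyl in place of hydrogen on an amine nitrogen, the same change made on the core of compound 2 rather than the core of compound 1. If the step carries over, compound 4 is expected to come out as 1600 nM, that is a 3.3-fold higher number from compound 2 to compound 4 (0.51 log units; beyond the scatter), with a plausible range from 700 nM to 3600 nM, because the same change gave a 3.3-fold higher number from compound 1 to compound 3 (0.52 log units; beyond the scatter) and compound 2 starts from 490 nM.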

Compound 4, half-maximal inhibitory concentration: 1010 nM
Beside the measured number, compound 4's estimate is 1.6-fold (0.20 log units) above it; the range from low to high includes it.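

Methyl in place of hydrogen on the amine nitrogen, now tried on the core of compound 2, gave in this assay (a 2.1-fold higher number from compound 2 to compound 4 (0.31 log units; beyond the scatter)) a weaker result, the same direction as on the core of compound 1. Set side by side, the two steps do not differ by more than repeated measurements normally would: the same change on two cores in this assay, a 3.3-fold higher number (0.52 log units; beyond the scatter) from compound 1 to compound 3 and a 2.1-fold higher number (0.31 log units; beyond the scatter) from compound 2 to compound 4, 1.6-fold (0.20 log units) apart, within the scatter of two such steps. So, for these two cores, the change carried over in both direction and size, which makes the step a fair guide within this pair; it does not show that the step would hold on a third core, and it does not explain why the added methyl weakens activity.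

The compounds shown leave open how far this trend runs on the same nitrogen: a second methyl, giving a dimethylamino group, or a longer chain such as ethyl could behave differently. They also leave open what happens if the amine is replaced altogether, for example by a hydroxyl group.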